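Silicon-aryl variation in a squalene monooxygenase inhibitor series

The source may hold more compounds than are shown below. What is called first, only, known or untested is meant among the compounds shown, and "the series" means these compounds.

The measured compounds are:
compound 1, `CCN(C/C=C/C#CC(C)(C)C)Cc1cccc(OC[Si](C)(C)c2cccc(C)c2)c1`, 3000 nM
compound 2, `CCN(C/C=C/C#CC(C)(C)C)Cc1cccc(OC[Si](C)(C)c2ccccc2C(F)(F)F)c1`, 70 nM
compound 3, `CCN(C/C=C/C#CC(C)(C)C)Cc1cccc(OC[Si](C)(C)c2ccc(C=O)cc2)c1`, 100 nM

In a functional assay on liver (Sus scrofa) for inhibition of squalene monooxygenase (Homo sapiens), using microsomes (a lower number here means a stronger inhibitor, a higher number a weaker inhibitor), compound 1 gives the highest of the three numbers. Two steps away from it have been measured: a 43-fold lower number from compound 1 to compound 2 (1.63 log units; beyond the scatter), and a 30-fold lower number from compound 1 to compound 3 (1.48 log units; beyond the scatter). Between compound 2 and compound 3 the step is a 1.4-fold higher number from compound 2 to compound 3 (0.15 log units; within the scatter), so both replacements of the 3-methylphenyl land close together.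

Compound 4, `CCN(C/C=C/C#CC(C)(C)C)Cc1cccc(OC[Si](C)(C)c2ccccc2-c2ccsc2)c1`, has not yet been measured. It differs from compound 1 by 2-(thiophen-3-yl)phenyl in place of 3-methylphenyl on a silicon. The two measured steps from compound 1 both bear on this change, since each also replaces the 3-methylphenyl on the silicon, and both were large and in the same direction. On that basis compound 4 is expected to give a markedly lower number than compound 1, a step of about a 15-fold lower number from compound 1 to compound 4 (1.18 log units; beyond the scatter). The value for compound 4 is estimated at 200 nM, with a range from 40 nM to 1500 nM.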

Compound 4, half-maximal inhibitory concentration: 10000 nM
Compound 4: the middle estimate sits 50-fold (1.70 log units) below what was measured; measured number outside the range, above it.
By their numbers in this assay, from the lowest: compounds 2 and 3 (each within the scatter of the next); then compound 1; then compound 4.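

Replacing the 3-methylphenyl on the silicon does not always lower the number in this assay: 2-(thiophen-3-yl)phenyl gives a 3.3-fold higher number from compound 1 to compound 4 (0.52 log units; beyond the scatter) and so runs against both earlier steps. Thiophen-3-yl in place of trifluoromethyl on an aromatic carbon gives a 140-fold higher number from compound 2 to compound 4 (2.15 log units; beyond the scatter) and 2-(thiophen-3-yl)phenyl in place of 4-formylphenyl on the silicon gives a 100-fold higher number from compound 3 to compound 4 (2.00 log units; beyond the scatter) in this assay, so the aryl group on the silicon separates these compounds widely. Nothing available accounts for this reversal.

The compounds shown leave open whether the higher number belongs to the sulfur-containing ring itself or to any aromatic ring at that aromatic carbon. A plain phenyl or a furan-3-yl in place of thiophen-3-yl would address this, and a chlorine there would show whether compound 2 stays close to such a smaller group.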